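Trimming the Trifluoromethyl Group on Compound 1

This account rests on a few compounds, and the source may have more. Where it says the series, first, only, none or still open, it means among the compounds named here.

Compound 1 `Cc1cc(CCC(=O)O)ccc1-c1noc(-c2ccc(OC(C)C)c(C(F)(F)F)c2)n1` stands as the more potent of the two measured compounds in a functional assay on CHO cells for agonist activity at sphingosine 1-phosphate receptor 5 (Homo sapiens), read by GTPgammaS binding (on this read-out higher numbers stand for an effect only at larger amounts of compound and lower numbers for an effect already at smaller amounts), where compound 1 gives 40 nM. Among the compounds with values here, its only measured neighbour is compound 2 `COc1ccc(-c2nc(-c3ccc(CCC(=O)O)cc3C)no2)cc1C(F)(F)F`, which in this assay gives 2600 nM. The step of a 65-fold higher number from compound 1 to compound 2 (1.81 log units; beyond the scatter) comes from a change at a different place, a methyl in place of an isopropyl on an oxygen on an aromatic ring. Compound 3 `Cc1cc(CCC(=O)O)ccc1-c1noc(-c2ccc(OC(C)C)c(F)c2)n1` differs from compound 1 in another way: fluoro in place of trifluoromethyl on an aromatic carbon. Within the data shown here, no measured step touches this position, so the one known step offers no direct guide and shows only that a change on this ring gave a large step. A moderate loss of potency is expected, amounting to a 3.8-fold higher number from compound 1 to compound 3 (0.57 log units; beyond the scatter). For compound 3 the estimated value in this assay is 150 nM, with a range from 40 nM to 600 nM.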

Compound 3, half-maximal effective concentration: 530 nM
Estimate against measurement, compound 3: 3.5-fold (0.55 log units) below; low and high end bracket the measured number.
By their numbers in this assay, from the lowest: compound 1; then compound 3; then compound 2.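

In this assay, the aromatic carbon ortho to the isopropoxy group now has a measured step of its own: fluoro in place of trifluoromethyl gives a 13-fold higher number from compound 1 to compound 3 (1.12 log units; beyond the scatter) and counts as a large step. This position is therefore sensitive to what sits on it. The swap removes three heavy atoms overall and changes no ring, hydrogen-bond donor, hydrogen-bond acceptor or net charge, yet this simple change still leaves compound 3 clearly behind compound 1. No measurement at hand explains the rise in the number.

The compounds shown leave open how a chloro group or a nitrile would behave on this carbon. They also leave open whether the fluoro swap would have a similar effect with a methoxy group in place of the isopropoxy group.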